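A few compounds are considered here, and "the series" means these few. Any claim that something is new, unique, unknown or untested is made for them only; others in the source may bear on it.

In an in vitro ADME assay on microsomes from liver (Mus musculus) for metabolic stability, tested at 0.2 uM (on this read-out higher numbers stand for fast clearance and lower numbers for slow clearance), the measured compounds stand as follows:
- compound 1 (`COc1ccc2[nH]c(COc3cccc(OCC4CCOCC4)c3)c(C)c(=O)c2c1`): ("not determined" (no result reported))
- compound 2 (`Cc1c(COCCCCO)[nH]c2ccccc2c1=O`): ("not determined" (no result reported))
- compound 3 (`Cc1c(COc2cccc(OCC3CCOCC3)n2)[nH]c2ccccc2c1=O`): (984 mL/min/kg)

Compound 2 therefore has no single number to start from, and compound 1 has none either. Only compound 3 gives a number, and it has a different side chain. Compound 4 (`Cc1c(COCCCCOCC2(C)COC2)[nH]c2ccccc2c1=O`) is still unmeasured. The change is hydroxy to (3-methyloxetan-3-yl)methoxy ((3-methyloxetan-3-yl)methyl in place of hydrogen on an oxygen on a saturated carbon). With no number for compound 2, the expected step in this assay can only be stated loosely, as a moderate rise towards faster clearance. The value of compound 3 (984 mL/min/kg) serves as the sole reference. Compound 4 is estimated at (400 mL/min/kg), with an expected range of (120 mL/min/kg to 1300 mL/min/kg).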

Compound 4, clearance: 295 mL/min/kg
The estimate for compound 4 lay 1.4-fold (0.13 log units) above the measured number; the range from low to high includes it.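

Within the data shown here, with no single number for compound 2, no step from it to compound 4 can be read. The effect of the (3-methyloxetan-3-yl)methyl group on clearance stays open, and nothing shown offers an explanation for the result.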